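This account rests on a few compounds, and the source may have more. Where it says the series, first, only, none or still open, it means among the compounds named here.

Measured in a functional assay on NCI-H460 cells (Homo sapiens) for cytotoxicity, read by MTT assay, with a stated time of 72 h; a higher number here means a weaker inhibitor, a lower number a stronger inhibitor:
- Compound 1 `O=c1[nH]/c(=C\c2nc[nH]c2C2CC2)c(=O)[nH]/c1=C\c1cccc(Oc2ccc(F)cc2)c1`: 15.2 nM
- Compound 2 `O=c1[nH]/c(=C\c2cccc(Oc3ccc(F)cc3)c2)c(=O)[nH]/c1=C\c1cccnc1`: > 1000 nM, a limit
- Compound 3 `O=c1[nH]/c(=C\c2cccs2)c(=O)[nH]/c1=C\c1cccc(Oc2ccc(F)cc2)c1`: > 1000 nM, a limit

The result for compound 3 is a limit of the assay, not a number. It is the limit of > 1000 nM in this assay, at which 2 of the 3 values shown sit.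

Compound 4 `O=c1[nH]/c(=C\c2ccc(Br)o2)c(=O)[nH]/c1=C\c1cccc(Oc2ccc(F)cc2)c1` differs from compound 3 by one change: 5-bromofuran-2-yl in place of thiophen-2-yl on a double-bonded chain carbon bound to an aromatic carbon.

Among the compounds with values here, two measured steps bear on this change, and both are large: an at least 65-fold higher number from compound 1 to compound 2 (1.81 log units; beyond the scatter), and an at least 65-fold higher number from compound 1 to compound 3 (1.81 log units; beyond the scatter). Each removes the 5-cyclopropyl-1H-imidazol-4-yl group, which compound 4 also lacks. The step that the two limits leave unreadable from compound 2 to compound 3 adds nothing further.

No clear gain in this assay is therefore expected, and the expected step is a step that the limit leaves unreadable from compound 3 to compound 4.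

For compound 4 the estimate is 1200 nM, with an expected range of 250 nM to 5000 nM.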

Compound 4, half-maximal inhibitory concentration: 361 nM
For compound 4 the middle estimate is 3.3-fold (0.52 log units) above the measured one, and the stated range covers the measured number.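

Compound 4 shows that a group other than 5-cyclopropyl-1H-imidazol-4-yl on this double-bonded chain carbon can give a readable number in this assay: 5-bromofuran-2-yl gives an at least 2.7-fold lower number from compound 3 to compound 4 (0.44 log units; beyond the scatter) and an at least 2.7-fold lower number from compound 2 to compound 4 (0.44 log units; beyond the scatter). Even so, the 5-cyclopropyl-1H-imidazol-4-yl group stays well ahead, with a 24-fold higher number from compound 1 to compound 4 (1.38 log units; beyond the scatter). Both of the first two steps are bounded, since compound 2 and compound 3 each stand at a limit, not a number: the limit of > 1000 nM in this assay, at which 2 of the 4 values shown sit.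

The change swaps sulfur for oxygen and adds bromine at once, and the compounds shown do not separate the two. Going by these compounds, whether an amine in place of the bromine would keep this result also stays open.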